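Swapping an ethoxy for an acetyl on the benzylamide ring

This account rests on a few compounds, and the source may have more. Where it says the series, first, only, none or still open, it means among the compounds named here.

Measured so far:
- compound 1 `C[S+]([O-])c1ccc(CNC(=O)c2ccc(C(C)(C)C)cc2)cc1`: 1300 nM
- compound 2 `CCOc1ccc(CNC(=O)c2ccc(C(C)(C)C)cc2)cc1`: 160 nM
- compound 3 `CC(C)(C)c1ccc(C(=O)NCc2ccc(N)cc2Cl)cc1`: 46 nM

These three share one core and differ only on the ring that carries the benzylic nitrogen. In an assay on HeLa cells with Bile acid receptor (Homo sapiens) as the target, read by a luciferase reporter, with a stated time of 24 h (on this read-out lower numbers stand for an effect already at smaller amounts and higher numbers for an effect only at larger amounts of compound), compound 2 stands second highest of the three numbers, with compound 3 giving a lower number and compound 1 a higher one. The unmeasured compound 4 `CC(=O)c1ccc(CNC(=O)c2ccc(C(C)(C)C)cc2)cc1` carries acetyl in place of ethoxy on an aromatic carbon. Within the data shown here, the one step that bears on this is an 8.1-fold lower number from compound 1 to compound 2 (0.91 log units; beyond the scatter), which also exchanged a group of three heavy atoms on the same aromatic carbon and moved the number well beyond the scatter. Because that step an 8.1-fold lower number from compound 1 to compound 2 (0.91 log units; beyond the scatter) shows this position to be sensitive, a change beyond the scatter is expected here too, and compound 4 is estimated at 450 nM (range 150 nM to 1400 nM), an expected step of a 2.8-fold higher number from compound 2 to compound 4 (0.45 log units; beyond the scatter).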

Compound 4, half-maximal effective concentration: 100 nM
Beside the measured number, compound 4's estimate is 4.5-fold (0.65 log units) above it, outside the stated range (below it).
By their numbers in this assay, from the lowest: compound 3; then compounds 4 and 2 (each within the scatter of the next); then compound 1.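

In this assay, acetyl in place of ethoxy on this aromatic carbon, para to a large group, gives a 1.6-fold lower number from compound 2 to compound 4 (0.20 log units; within the scatter), so this exchange moves the number no further than the usual scatter. The position therefore does not respond to every exchange of a group of this size, while the sulfur-bearing group of compound 1 stands apart, with a 13-fold lower number from compound 1 to compound 4 (1.11 log units; beyond the scatter). Nothing measured here explains why these groups differ. As far as these compounds go, how a carboxylic acid, a nitrile or a longer chain on this same aromatic carbon would read remains open.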